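Methoxy to hydroxy in a series sitting at the assay limit

The source may report more compounds than this note shows. Statements on the series, on what has been measured and on what is new or still open speak of the compounds shown alone.

compound 1 `C=CC(=O)N(CC(=O)OC)c1nc(-c2ccccc2)cs1`: > 30000 nM
compound 2 `C=CC(=O)N(CC(=O)O)c1nc(-c2ccccc2)cs1`: > 30000 nM
compound 3 `C=CC(=O)N(Cc1cc(C)no1)c1nc(-c2ccccc2OC)cs1`: > 30000 nM

In a functional assay on HCT-116 cells (Homo sapiens) for antiproliferative activity, read by MTT assay, with a stated time of 72 h (a lower number here means a stronger inhibitor, a higher number a weaker inhibitor), compound 1 gives > 30000 nM, a limit of the assay rather than a number. Compound 2 likewise gives > 30000 nM, again only a limit. Compound 3 gives > 30000 nM, also a limit. The step that the two limits leave unreadable from compound 1 to compound 2 is therefore unreadable; the change is hydrogen in place of methyl on an oxygen next to a carbonyl group. Compound 4 `C=CC(=O)N(Cc1cc(C)no1)c1nc(-c2ccccc2O)cs1` is not yet measured; it differs from compound 3 by hydrogen in place of methyl on an oxygen on an aromatic ring, the same kind of change, though here the oxygen sits on an aromatic ring with an aromatic carbon as its other neighbour rather than next to a carbonyl group. The difference between the cores of compound 1 and compound 3 is not broken down here. Among the compounds with values here, with the limit of > 30000 nM in this assay, at which 3 of the 3 values shown sit, no step in this assay has been readable, so a limit is again expected for compound 4. Compound 4 is expected to give 35000 nM, between 12000 nM and 100000 nM, an estimated step that the limit leaves unreadable from compound 3 to compound 4.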

Compound 4, half-maximal inhibitory concentration: > 30000 nM
Compound 4: only a limit was reported; the forecaster's own chance of this, stated with the estimate: 80%; the middle value lies beyond the limit too.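

In this assay compound 4 gives > 30000 nM, a limit and not a number. No size can be read for the methoxy to hydroxy change between compound 3 and compound 4: the limit of > 30000 nM in this assay, at which 4 of the 4 values shown sit.

Going by these compounds, whether any change to the shared core brings a value inside the limit stays open.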